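Methyl for hydrogen on the aromatic ring of compound 2

The compounds below may be only part of what the source reports. "The series", "measured", "known", "first", "only" and "open" are said of these compounds alone.

Measured compounds in a functional assay on HeLa cells (Homo sapiens) for cytotoxicity, read by sulforhodamine B assay; on this read-out higher numbers stand for weaker inhibition and lower numbers for stronger inhibition:
compound 1 `Cc1ccc2c3c(n(C)c(=O)c2c1)-c1ccccc1OCC3` gives 8760 nM
compound 2 `COc1ccc(Cn2c3c(c4ccccc4c2=O)CCOc2ccccc2-3)cc1` gives 4780 nM

Compound 2 holds the lowest of the two numbers in this assay, but its nearest neighbour, compound 1, sits within the usual scatter of it, so no order between the two can be read from these numbers. Compound 1 and compound 2 differ in two places, and the two values show only that both lie in the same low-micromolar region.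

Compound 3 `COc1ccc(Cn2c3c(c4ccc(C)cc4c2=O)CCOc2ccccc2-3)cc1` is not yet measured. It keeps the whole of compound 2 and changes one position: methyl in place of hydrogen on an aromatic carbon. Compound 1 already carries a methyl on the aromatic ring of the shared core and gives 8760 nM, a number within scatter of compound 2; this is the only hint available, and it points to a small effect of this group in this assay.

The step from compound 2 to compound 3 in this assay is therefore expected to be small, a 1.0-fold higher number from compound 2 to compound 3 (0.02 log units; within the scatter), not clearly beyond the scatter in either direction. Compound 3 is estimated at 5000 nM, with a range from 2000 nM to 12000 nM.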

Compound 3, half-maximal inhibitory concentration: 4540 nM
Compound 3: the middle estimate sits 1.1-fold (0.04 log units) above what was measured, and the stated range covers the measured number.
By their numbers in this assay, from the lowest: compounds 3, 2 and 1 (each within the scatter of the next).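

In this assay, methyl in place of hydrogen on this aromatic carbon now has a step of its own, a 1.1-fold lower number from compound 2 to compound 3 (0.02 log units; within the scatter), where compound 1 offered only a hint, since it differs from compound 2 in two places. Compound 3 also pairs with compound 1, showing 4-methoxyphenyl in place of hydrogen on a saturated chain carbon bound to an aromatic nitrogen as a single change, a 1.9-fold lower number from compound 1 to compound 3 (0.29 log units; within the scatter), so neither single change gives a step beyond the scatter in this assay. No measurement given here bears on the reason for the size of either step.

Whether any group on this aromatic carbon gives a step beyond the scatter remains open, since methyl is the only replacement for hydrogen shown there, and an amine or a carboxylic acid could be read against compound 2. Going by these compounds, on the saturated chain carbon bound to the aromatic nitrogen, it also remains open how a longer chain or an amine in place of 4-methoxyphenyl would compare with compound 3.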